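Methylsulfanyl in place of methyl on compound 3

This account rests on a few compounds, and the source may have more. Where it says the series, first, only, none or still open, it means among the compounds named here.

In a functional assay on SW-620 cells (Homo sapiens) for cytotoxicity (on this read-out higher numbers stand for weaker inhibition of growth and lower numbers for stronger inhibition of growth), compound 3 `CSc1ccc(C2=C(c3ccc(C)cc3)C(=O)N3CCCC3C2)cc1` gives 3000 nM. Compound 2 `COc1ccc(C2=C(c3ccc(SC)cc3)CC3CCCN3C2=O)cc1` gives 3000 nM, level with compound 3 at the digits shown, and these two share the lowest number of the three measured. Compound 1 `COc1ccc(C2=C(c3ccc(SC)cc3)CC3CCCN3C2=O)cc1O` gives 20000 nM.

The next structure is compound 4 `CSc1ccc(C2=C(c3ccc(SC)cc3)C(=O)N3CCCC3C2)cc1`, which carries methylsulfanyl in place of methyl on an aromatic carbon, para to a large group: methylsulfanyl in place of methyl on an aromatic carbon.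

For the measured compounds named here, the closest precedent is no change at the digits printed from compound 2 to compound 3 (within the scatter), with methyl in place of methoxy on an aromatic carbon. The other two measured steps both start from compound 1, which has a hydroxy group that compound 3 and compound 4 lack. They are a 6.7-fold lower number from compound 1 to compound 2 (0.82 log units; beyond the scatter), with hydrogen in place of hydroxy, and a 6.7-fold lower number from compound 1 to compound 3 (0.82 log units; beyond the scatter), with 4-methylphenyl in place of 3-hydroxy-4-methoxyphenyl. These modest steps say little about the present change. Going by the values given here, no measured step exchanges methylsulfanyl for another group, so the expectation rests on a single swap.

No step beyond the scatter is expected in this assay, in either direction. The expected step is no change at the digits printed from compound 3 to compound 4 (within the scatter). Compound 4 is estimated at 3000 nM, with an expected range of 1000 nM to 9000 nM.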

Compound 4, concentration for 50% growth inhibition: 7000 nM
For compound 4 the middle estimate is 2.3-fold (0.37 log units) below the measured one; the range from low to high includes it.
By their numbers in this assay, from the lowest: compounds 2 and 3 (each within the scatter of the next); then compound 4; then compound 1.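

In this assay this position is shown to respond to the group it carries: the exchange gives a 2.3-fold higher number from compound 3 to compound 4 (0.37 log units; beyond the scatter) and so differs from the earlier swap of methyl for methoxy, which gave no change at the digits printed from compound 2 to compound 3 (within the scatter). The same higher number appears against the methoxy compound (a 2.3-fold higher number from compound 2 to compound 4 (0.37 log units; beyond the scatter)), so methoxy and methyl stay level here while methylsulfanyl separates from both, though the step remains modest and compound 4 still sits on the lower side of the hydroxy-bearing compound (a 2.9-fold lower number from compound 1 to compound 4 (0.46 log units; beyond the scatter)). Nothing available gives a reason for these differences, and the series offers only the numbers themselves.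

Going by these compounds, the three compounds compared at this position all carry methylsulfanyl on the other aromatic ring, so it remains open whether the same steps would hold with a different group there. It also remains open how an amine, a carboxylic acid or a longer chain such as ethylsulfanyl would read at this position, since the groups shown span only methyl, methoxy and methylsulfanyl.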